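A few compounds are considered here, and "the series" means these few. Any claim that something is new, unique, unknown or untested is made for them only; others in the source may bear on it.

Working notes on the series. The core is shared by all three measured compounds: compound 1 `Fc1ccccc1NC(=S)Nc1cccc(C(F)(F)F)c1`, compound 2 `FC(F)(F)c1cccc(NC(=S)Nc2ccc(I)cc2)c1` and compound 3 `FC(F)(F)c1cccc(NC(=S)Nc2ccccc2Br)c1`. In an ADME assay on MT4 cells (Homo sapiens) for cytotoxicity (a higher number here means that more compound is tolerated, a lower number that less compound is tolerated), compound 1 gives 47000 nM, compound 2 gives 10000 nM and compound 3 gives 36000 nM. Compound 2 therefore stands lowest of the three numbers, with compound 3 nearest at a 3.6-fold higher number from compound 2 to compound 3 (0.56 log units; beyond the scatter) and compound 1 furthest at a 4.7-fold lower number from compound 1 to compound 2 (0.67 log units; beyond the scatter). Between compound 1 and compound 3 the step is small, a 1.3-fold lower number from compound 1 to compound 3 (0.12 log units; within the scatter).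

Compound 4 `N#Cc1ccc(NC(=S)Nc2cccc(C(F)(F)F)c2)cc1` is not yet measured. It differs from compound 2 in one place: cyano in place of iodo on an aromatic carbon, on an aromatic carbon of a six-membered aromatic ring of carbon only, para to a large group. Going by the values given here, no measured step exchanges iodo for cyano, so the two steps that lead away from compound 2 are the only ones that bear on it; both are modest and both run upward. Leaving the iodo behind is expected to move the number back toward the range of compound 1 and compound 3, so the expected step is a 2.5-fold higher number from compound 2 to compound 4 (0.40 log units; beyond the scatter). Compound 4 is estimated at 25000 nM, within 10000 nM to 60000 nM.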

Compound 4, half-maximal cytotoxic concentration: 7000 nM
The estimate for compound 4 lay 3.6-fold (0.55 log units) above the measured number; the whole stated range lies above it.
By their numbers in this assay, from the lowest: compounds 4 and 2 (each within the scatter of the next); then compounds 3 and 1 (each within the scatter of the next).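

In this assay, the exchange of iodo for cyano, on an aromatic carbon para to a large group, gives a 1.4-fold lower number from compound 2 to compound 4 (0.15 log units; within the scatter), so this position accepts the change without a separable shift in the number. The earlier steps shown here changed the halogen and its place together and could not separate the two; this step keeps the place fixed and shows that the low number of compound 2 does not depend on iodo itself. Nothing at hand explains why these two groups read alike.

Still open, from the compounds shown here alone, is whether a smaller group such as fluoro, or a charged one such as a carboxylic acid or an amine, would read the same in this place. Going by these compounds, it is also open whether cyano would keep this number in another place on the ring.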